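This account rests on a few compounds, and the source may have more. Where it says the series, first, only, none or still open, it means among the compounds named here.

Values measured so far:

- Compound 1 `Cc1ccc(S(=O)(=O)/C(=C/c2ccc(N(C)C)cc2)C(=O)c2ccc(Cl)cc2)cc1`: > 100000 nM
- Compound 2 `CN(C)c1ccc(/C=C(/SCc2ccc(Cl)cc2)C(=O)c2ccc(Cl)cc2)cc1`: > 100000 nM
- Compound 3 `CN(C)c1ccc(/C=C(/SCc2ccc(Cl)c(Cl)c2)C(=O)c2ccc(Cl)cc2)cc1`: 50000 nM

All three compounds were tested in a functional assay on DU-145 cells (Homo sapiens) for inhibition, read by trypan blue exclusion, with a stated time of 96 h; a lower number here means a stronger inhibitor of growth, a higher number a weaker inhibitor of growth. Compound 1 stands at > 100000 nM, which is a limit of the assay and not a number. Compound 2 stands at > 100000 nM, which is also a limit. Only compound 3 gives a number.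

Compound 4 `Cc1ccc(S(=O)(=O)/C(=C/c2cc(C)cc(C)c2)C(=O)c2ccc(Cl)cc2)cc1` keeps the core of compound 1 and differs from it as follows: 3,5-dimethylphenyl in place of 4-(dimethylamino)phenyl on a double-bonded chain carbon bound to a double-bonded chain carbon. Among the compounds with values here, all three measured compounds carry 4-(dimethylamino)phenyl, so no measured step changes that group. The measured steps lie elsewhere: a step that the two limits leave unreadable from compound 1 to compound 2, an at least 2.0-fold lower number from compound 1 to compound 3 (0.30 log units; that floor lies within the scatter) and an at least 2.0-fold lower number from compound 2 to compound 3 (0.30 log units; that floor lies within the scatter). They therefore give no direct measure of the new change. With compound 1 at the limit of > 100000 nM in this assay, at which 2 of the 3 values shown sit, no step beyond the scatter is expected in this assay, and compound 4 may well remain at the limit.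

The estimate for compound 4 is 60000 nM, with an expected range from 15000 nM to 100000 nM. This estimate corresponds to an at least 1.6-fold lower number from compound 1 to compound 4 (0.22 log units; that floor lies within the scatter).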

Compound 4, concentration for 50% growth inhibition: 1000 nM
The estimate for compound 4 lay 60-fold (1.78 log units) above the measured number; measured number below the stated range.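

In this assay, 3,5-dimethylphenyl in place of 4-(dimethylamino)phenyl on a double-bonded chain carbon bound to a double-bonded chain carbon gives an at least 100-fold lower number from compound 1 to compound 4 (2.00 log units; beyond the scatter). Within the data shown here, all the earlier compounds carried 4-(dimethylamino)phenyl here, so this is the first sign that this position can strongly shift growth inhibition, and that a compound with (4-methylphenyl)sulfonyl need not stay inactive. The step is only a floor, and its true size cannot be read: the limit of > 100000 nM in this assay, at which 2 of the 4 values shown sit.

The compounds shown leave open whether the gain comes from the two methyl groups or from the loss of the dimethylamino group, a question that a plain phenyl or a 3,5-dimethoxyphenyl group at this position would address. They also leave open whether 3,5-dimethylphenyl would act the same way alongside (3,4-dichlorobenzyl)sulfanyl.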